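Replacing the Ketone Link with a Trifluoromethylbenzyl Group

The source may hold more compounds than are shown below. What is called first, only, known or untested is meant among the compounds shown, and "the series" means these compounds.

Measured so far:
Compound 1 `COc1cc(OC)c(-c2coc3cc(OCC(=O)c4cccc(C(F)(F)F)c4)ccc3c2=O)cc1OC`: > 10000 nM
Compound 2 `COc1cc(OC)c(-c2coc3cc(OCc4ccccc4C#N)ccc3c2=O)cc1OC`: 2140 nM

Two compounds share a core and differ only in the group on a saturated chain carbon bound to an oxygen on an aromatic ring. In a functional assay on B16 cells (Mus musculus) for antiproliferative activity, read by MTT assay, with a stated time of 24 h (a higher number here means a weaker inhibitor, a lower number a stronger inhibitor), compound 1 gives > 10000 nM, which is a limit of the assay rather than a number. Compound 2 gives 2140 nM. Among the measured compounds shown here, the one measured step, an at least 4.6-fold lower number from compound 1 to compound 2 (0.66 log units; beyond the scatter), is known only as a minimum because compound 1 sits at the limit of > 10000 nM in this assay, at which 1 of the 2 values shown sits.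

Compound 3 `COc1cc(OC)c(-c2coc3cc(OCc4ccc(C(F)(F)F)cc4)ccc3c2=O)cc1OC` has not yet been measured. It differs from compound 1 as follows: 4-(trifluoromethyl)phenyl in place of (3-(trifluoromethyl)phenyl)carbonyl on a saturated chain carbon bound to an oxygen on an aromatic ring. For the measured compounds named here, as in the step to compound 2, the carbonyl leaves and a single substituted aromatic ring remains directly on the chain carbon, so that step is the only guide, and it points downward by a modest but uncertain amount.

Compound 3 is therefore expected to give about 3000 nM, within 1000 nM to 10000 nM. The expected step is an at least 3.3-fold lower number from compound 1 to compound 3 (0.52 log units; beyond the scatter).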

Compound 3, half-maximal inhibitory concentration: 5400 nM
Compound 3: middle estimate off by 1.8-fold (0.26 log units), on the low side; the measured number falls inside the stated range.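

In this assay, taking out the carbonyl and setting an aromatic ring directly on the chain carbon now has a second example, but the size of the gain stays uncertain: the step is an at least 1.8-fold lower number from compound 1 to compound 3 (0.26 log units; that floor lies within the scatter). Among the compounds shown here, only this floor can be read, and the real step may be larger, because compound 1 has no exact number: the limit of > 10000 nM in this assay, at which 1 of the 3 values shown sits. The new result also gives the first comparison of two compounds that both lack the carbonyl, and it shows that the choice of aromatic group still matters after that change, with a 2.5-fold higher number from compound 2 to compound 3 (0.40 log units; beyond the scatter).

What the compounds shown leave open is whether this last difference comes from the kind of group, nitrile or trifluoromethyl, or from where it sits on the ring, as 2-cyanophenyl and 4-(trifluoromethyl)phenyl differ in both. A 4-cyanophenyl or 2-(trifluoromethyl)phenyl group would separate these two factors, and an unsubstituted phenyl group would show whether either substituent helps at all.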